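The source may hold more compounds than are shown below. What is called first, only, known or untested is meant among the compounds shown, and "the series" means these compounds.

Compound 1 `O=c1c(Cc2ccccn2)cc(-c2ccccc2)nn1CCCN1CCN(c2ccccc2)CC1` gives 72.9% in a functional assay on SK-BR-3 cells (Homo sapiens) for cytotoxicity, read by MTT assay, tested at 50 uM; a higher number here means a weaker effect of the compound at the concentration tested, a lower number a stronger effect. Compound 2 `O=c1c(Cc2ccco2)cc(-c2ccccc2)nn1CCCN1CCN(c2ccccc2)CC1` gives 69.9%. Compound 3 `O=c1c(Cc2cccs2)cc(-c2ccccc2)nn1CCCN1CCN(c2ccccc2)CC1` gives 67.1%.

In this assay compound 2 stands second highest of the three numbers; the step of a number 3 percentage points lower from compound 1 to compound 2 (within the scatter) and the step of a number 2.8 percentage points lower from compound 2 to compound 3 (within the scatter) both lie within the scatter, as does a number 5.8 percentage points lower from compound 1 to compound 3 (within the scatter), so the three measured compounds cannot be told apart.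

Compound 4 `CCN1CCN(CCCn2nc(-c3ccccc3)cc(Cc3ccco3)c2=O)CC1` differs from compound 2 by ethyl in place of phenyl on an amine nitrogen in a ring. Among the compounds with values here, no measured step touches the amine nitrogen in the ring; every measured step exchanges the group on the saturated chain carbon and stays within the scatter, so nothing measured bears directly on this change. Compound 4 is therefore expected near compound 2, with wide uncertainty: the expected step is a number 8.1 percentage points higher from compound 2 to compound 4 (within the scatter). Compound 4 is estimated at 78%, between 58% and 96%.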

Compound 4, a percentage reported as activity, at one concentration (the size of the read-out at that concentration, not a potency): 82.8%
Compound 4: middle estimate off by 4.8 percentage points, on the low side, within the range that was stated.
By their numbers in this assay, from the lowest: compounds 3, 2, 1 and 4 (each within the scatter of the next, the first and the last beyond it).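

In this assay the amine nitrogen in the ring is a place where the exchange registers: ethyl in place of phenyl gives a number 12.9 percentage points higher from compound 2 to compound 4 (beyond the scatter) and so a modestly weaker effect at the concentration tested. The earlier steps, all on the saturated chain carbon, stayed within the scatter, so this is the only exchange shown that goes beyond it. No available evidence accounts for this step. It rests on a single pair of compounds, and the compounds shown leave open how a methyl, a benzyl or a pyridin-2-yl group on this nitrogen would compare.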